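The source may report more compounds than this note shows. Statements on the series, on what has been measured and on what is new or still open speak of the compounds shown alone.

Measured so far in an ADME assay on L02 cells (Homo sapiens) for inhibition, read by MTT assay, with a stated time of 72 h; on this read-out lower numbers stand for stronger inhibition and higher numbers for weaker inhibition:
- compound 1 `CN(C(=O)NC(=O)c1ccc(C(F)(F)F)cc1)c1nc(C(F)(F)F)c(C(=O)N/N=C/c2ccc(C(F)(F)F)cc2)s1`: "not determined" (no result reported)
- compound 2 `CN(C(=O)NC(=O)c1ccc(C(F)(F)F)cc1)c1nc(C(F)(F)F)c(C(=O)N/N=C/c2cccc(C(F)(F)F)c2)s1`: 18 ug/mL
- compound 3 `CN(C(=O)NC(=O)c1c(Cl)cccc1Cl)c1nc(C(F)(F)F)c(C(=O)N/N=C/c2ccccc2C(F)(F)F)s1`: "not determined" (no result reported)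

For compound 3 this assay gives "not determined" (no result reported). For compound 1 this assay gives "not determined" (no result reported). Among the compounds with values here, the only value in the set is that of compound 2, for which this assay gives 18 ug/mL. Compound 3 has no number. No measured starting point exists from which the step to the next compound could be sized.

Compound 4 `CN(C(=O)NC(=O)c1ccc(C(F)(F)F)cc1)c1nc(C(F)(F)F)c(C(=O)N/N=C/c2ccccc2C(F)(F)F)s1` differs from compound 3 in one place: 4-(trifluoromethyl)phenyl in place of 2,6-dichlorophenyl on a carbonyl carbon. Within the data shown here, no step between two measured compounds is known, so no expected size or direction for this change can be drawn from the data; nothing beyond the usual scatter is assumed. Among the measured compounds shown here, compound 4 shares the (4-(trifluoromethyl)phenyl)carbonyl part with compound 2, and compound 2 is the only compound with a number in this assay, so the expectation for compound 4 is anchored there, with a wide range to reflect the absence of any measured step. Compound 4 is expected to give about 18 ug/mL in this assay, with a range from 6 ug/mL to 60 ug/mL.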

Compound 4, half-maximal inhibitory concentration: 12.4 ug/mL
Compound 4: the middle estimate sits 1.5-fold (0.16 log units) above what was measured; low and high end bracket the measured number.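

Within the data shown here, the first step that can be read in this assay is a 1.5-fold lower number from compound 2 to compound 4 (0.16 log units; within the scatter), so at the carbon with a double bond to nitrogen, this read-out does not separate 2-(trifluoromethyl)phenyl from 3-(trifluoromethyl)phenyl when the (4-(trifluoromethyl)phenyl)carbonyl part is held constant. The change from 2,6-dichlorophenyl to 4-(trifluoromethyl)phenyl on the carbonyl carbon cannot be read, as compound 3 has no number, and so the data give no size or direction for it. Nothing measured here bears on the result at the carbon with a double bond to nitrogen.

With the (4-(trifluoromethyl)phenyl)carbonyl part held constant, the third placement of the trifluoromethyl group also stays without a number, since in this assay compound 1 gives "not determined" (no result reported). Still open, from the compounds shown here alone, is whether a phenyl ring carrying a carboxylic acid, an amine or a nitrile in place of trifluoromethyl at the carbon with a double bond to nitrogen would stay within the usual scatter of these values or move clearly away from them.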